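Hydroxymethyl in place of penta-1,3-dien-1-yl on a carbonyl carbon

This account rests on a few compounds, and the source may have more. Where it says the series, first, only, none or still open, it means among the compounds named here.

In a functional assay on MGC-803 cells (Homo sapiens) for inhibition, read by MTT assay, with a stated time of 48 h (on this read-out higher numbers stand for weaker inhibition and lower numbers for stronger inhibition), compound 1 `COCC(=O)N(Cc1ccc(OC)c(O)c1)c1cc(OC)c(OC)c(OC)c1` gives 79 nM, compound 2 `C#CC(=O)N(Cc1ccc(OC)c(O)c1)c1cc(OC)c(OC)c(OC)c1` gives 170 nM, and compound 3 `C/C=C/C=C/C(=O)N(Cc1ccc(OC)c(O)c1)c1cc(OC)c(OC)c(OC)c1` gives 140 nM. Compound 3 thus sits within the scatter of both others, as shown by a 1.8-fold higher number from compound 1 to compound 3 (0.25 log units; within the scatter) and a 1.2-fold lower number from compound 2 to compound 3 (0.08 log units; within the scatter). Only a 2.2-fold higher number from compound 1 to compound 2 (0.33 log units; beyond the scatter) passes beyond the scatter, and modestly. Compound 4 `COc1ccc(CN(C(=O)CO)c2cc(OC)c(OC)c(OC)c2)cc1O` carries hydroxymethyl in place of penta-1,3-dien-1-yl on a carbonyl carbon. The measured group nearest to hydroxymethyl is the methoxymethyl of compound 1, and a 1.8-fold higher number from compound 1 to compound 3 (0.25 log units; within the scatter) is small, so only a slight shift towards compound 1 is expected. The estimated step is a 1.4-fold lower number from compound 3 to compound 4 (0.15 log units; within the scatter). Compound 4 is expected at 100 nM, with an estimated range of 40 nM to 250 nM.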

Compound 4, half-maximal inhibitory concentration: 160 nM
Compound 4: the middle estimate sits 1.6-fold (0.20 log units) below what was measured; the measured number falls inside the stated range.
By their numbers in this assay, from the lowest: compounds 1, 3, 4 and 2 (each within the scatter of the next, the first and the last beyond it).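

In this assay, hydroxymethyl on a carbonyl carbon cannot be told apart from penta-1,3-dien-1-yl (a 1.1-fold higher number from compound 3 to compound 4 (0.06 log units; within the scatter)) or from ethynyl (a 1.1-fold lower number from compound 2 to compound 4 (0.03 log units; within the scatter)), so this position accepts these three unlike groups with no readable change. What is new is the pair that differs only at the oxygen of the side chain: hydrogen in place of methyl there gives a modest step beyond the scatter (a 2.0-fold higher number from compound 1 to compound 4 (0.31 log units; beyond the scatter)), and methoxymethyl in compound 1 keeps the lowest number of the four. On these data alone, whether an amine or a longer ether chain at this position would match compound 1 remains open. Nothing available here accounts for the step at that oxygen.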